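The compounds below may be only part of what the source reports. "The series", "measured", "known", "first", "only" and "open" are said of these compounds alone.

Of the compounds shown here, three have so far been tested in a functional assay on L02 cells (Homo sapiens) for inhibition, read by MTT assay, with a stated time of 48 h; a higher number here means a weaker inhibitor, a lower number a stronger inhibitor. Compound 1 `COc1ccc2c(=O)c(/C=C/C(=O)Nc3ccc(Cl)cc3)coc2c1` gives a result that is only a limit of the assay, > 200000 nM. Compound 2 `CCOc1ccc(NC(=O)/C=C/c2coc3cc(OC)ccc3c2=O)cc1` likewise gives only a limit, > 200000 nM. Compound 3 `COc1ccc2c(=O)c(/C=C/C(=O)NCc3ccc(C)cc3)coc2c1` also gives only a limit, > 200000 nM. Going by the values given here, because every value so far sits at that same limit (the limit of > 200000 nM in this assay, at which 3 of the 3 values shown sit), the steps between these compounds cannot be sized: a step that the two limits leave unreadable from compound 1 to compound 2, a step that the two limits leave unreadable from compound 1 to compound 3 and a step that the two limits leave unreadable from compound 2 to compound 3. Compound 3 therefore stands at the limit, indistinguishable on the numbers shown from the other two.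

Compound 4 `COc1ccc(NC(=O)/C=C/c2coc3cc(OC)ccc3c2=O)cc1` has not yet been measured in this assay. 4-methoxyphenyl in place of 4-methylbenzyl on an amide-type nitrogen None of the three measured steps has a readable size, so none offers a direction for this change, and nothing among the shown compounds suggests that a change on the amide-type nitrogen moves a compound away from the limit. The step from compound 3 to compound 4 is accordingly expected to be a step that the limit leaves unreadable from compound 3 to compound 4, nothing beyond the scatter. Compound 4 is expected to give an estimated 250000 nM, with a range from 80000 nM to 1000000 nM, most likely reported again only as a limit.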

Compound 4, half-maximal inhibitory concentration: > 200000 nM
Compound 4: only a limit was reported; the forecaster's own chance of this, stated with the estimate: 85%; the middle value is on the limit's open side.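

In this assay compound 4 gives > 200000 nM, which is only a limit. No new step can be read between compound 4 and compound 1, compound 2 or compound 3, because all of them sit at the same limit: the limit of > 200000 nM in this assay, at which 4 of the 4 values shown sit. The compounds shown leave open whether any change on the amide-type nitrogen can move a compound away from that limit.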